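This account rests on a few compounds, and the source may have more. Where it says the series, first, only, none or still open, it means among the compounds named here.

Measured compounds:
- compound 1 `CCCCCCNC(=O)n1cc(OC)c(=O)[nH]c1=O`: 1100 nM
- compound 2 `CCCCCCNC(=O)n1cc(F)c(=O)n(CC)c1=O`: 18 nM
- compound 3 `CCCCCCNC(=O)n1cc(F)c(=O)n(CC2CC2)c1=O`: 61 nM

All three share the hexylcarbamoyl core and were tested in an assay on HEK293 cells for inhibition of acid ceramidase (Rattus norvegicus), read by LC-MS, with a stated time of 30 min; a higher number here means a weaker inhibitor, a lower number a stronger inhibitor. For the measured compounds named here, compound 3 stands second highest of the three numbers: compound 2 sits closest, and the one measured step that is fully single-point, a 3.4-fold higher number from compound 2 to compound 3 (0.53 log units; beyond the scatter), is a modest change beyond the scatter. Compound 1 is furthest away; it differs from compound 3 in two places at once (methoxy in place of fluoro and a ring nitrogen carrying hydrogen in place of the cyclopropylmethyl), so its much higher value cannot be assigned to either change alone.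

The next compound, compound 4 `CCCCCCNC(=O)n1cc(F)c(=O)n(C(=O)OC)c1=O`, differs from compound 3 in one place: methoxycarbonyl in place of cyclopropylmethyl on an aromatic nitrogen. Going by the values given here, no measured step describes an exchange of this kind on the ring nitrogen; the only step bearing on substitution at that position is a 3.4-fold higher number from compound 2 to compound 3 (0.53 log units; beyond the scatter), which shows that swapping one small group for another there shifts the number only modestly. Any change beyond that size in this assay would be outside what the measured pairs support, in either direction.

Compound 4 is therefore expected to land in the general range of compounds 2 and 3, with the estimate for compound 4 put at 100 nM (range 20 nM to 600 nM), which corresponds to an expected step of a 1.6-fold higher number from compound 3 to compound 4 (0.21 log units; within the scatter).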

Compound 4, half-maximal inhibitory concentration: 7 nM
Beside the measured number, compound 4's estimate is 14-fold (1.15 log units) above it; measured number outside the range, below it.
By their numbers in this assay, from the lowest: compound 4; then compound 2; then compound 3; then compound 1.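

In this assay, for the compounds shown here, the substituent on the aromatic nitrogen can now be seen to move the number in both directions: the only earlier step at this position was upward, a 3.4-fold higher number from compound 2 to compound 3 (0.53 log units; beyond the scatter), while methoxycarbonyl in place of cyclopropylmethyl gives an 8.7-fold lower number from compound 3 to compound 4 (0.94 log units; beyond the scatter). The two groups have the same count of 4 heavy atoms, so within this pair the size of the shift does not follow heavy-atom count; the change also removes the three-membered ring and brings in oxygen, a double bond outside aromatic rings and hydrogen-bond acceptors. Methoxycarbonyl in place of ethyl gives a 2.6-fold lower number from compound 2 to compound 4 (0.41 log units; beyond the scatter), so the lower number also holds against the smaller alkyl group, and no measurement shown here accounts for either step.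

Which feature of methoxycarbonyl goes with the lower number remains open, and an acetyl, an ethoxycarbonyl or a dimethylcarbamoyl group on the same nitrogen would help separate the carbonyl from the ester oxygen. Also open, from the compounds shown here alone, is whether the order of these nitrogen substituents would persist with methoxy in place of the fluoro group on the shared core.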